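Chain series: from compound 1 to compound 4

This account rests on a few compounds, and the source may have more. Where it says the series, first, only, none or still open, it means among the compounds named here.

compound 1 `O=C(CCCCOc1no[n+]([O-])c1S(=O)(=O)c1ccccc1)NO` gives 2530 nM
compound 2 `O=C(CCCCCCOc1no[n+]([O-])c1S(=O)(=O)c1ccccc1)NO` gives 1210 nM
compound 3 `O=C(CCCCCCCOc1no[n+]([O-])c1S(=O)(=O)c1ccccc1)NO` gives 2700 nM

In a functional assay on MDA cells (Homo sapiens) for inhibition, read by MTT assay, with a stated time of 48 h (on this read-out lower numbers stand for stronger inhibition and higher numbers for weaker inhibition), compound 1 belongs to the upper pair of numbers, with a 1.1-fold higher number from compound 1 to compound 3 (0.03 log units; within the scatter) within the scatter, while a 2.1-fold lower number from compound 1 to compound 2 (0.32 log units; beyond the scatter) is a modest step beyond it. Next is compound 4 `O=C(/C=C/COc1no[n+]([O-])c1S(=O)(=O)c1ccccc1)NO`, with this change on a saturated chain carbon bound to an oxygen on an aromatic ring: 2-(hydroxycarbamoyl)ethenyl in place of 3-(hydroxycarbamoyl)propyl on a saturated chain carbon bound to an oxygen on an aromatic ring. The nearest evidence is the chain steps, with a 2.2-fold higher number from compound 2 to compound 3 (0.35 log units; beyond the scatter) also modest. Going by the values given here, no measured compound carries the 2-(hydroxycarbamoyl)ethenyl group, so the direction remains uncertain. A modest rise is expected in this assay, given as the estimated 1.4-fold higher number from compound 1 to compound 4 (0.14 log units; within the scatter). Compound 4 is estimated at 3500 nM, with an expected range of 1300 nM to 9500 nM.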

Compound 4, half-maximal inhibitory concentration: 47700 nM
Beside the measured number, compound 4's estimate is 14-fold (1.13 log units) below it; the measured number lies above the stated range.
By their numbers in this assay, from the lowest: compound 2; then compounds 1 and 3 (each within the scatter of the next); then compound 4.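

In this assay, 2-(hydroxycarbamoyl)ethenyl in place of 3-(hydroxycarbamoyl)propyl gives a 19-fold higher number from compound 1 to compound 4 (1.28 log units; beyond the scatter) as a large step, whereas the steps among compound 1, compound 2 and compound 3 are modest or within the scatter. This place on the chain therefore responds far more to this change than to any of the saturated chain lengths shown. Nothing at hand accounts for the size of this step. The compounds shown do not separate the double bond from the shorter chain, which a saturated 2-(hydroxycarbamoyl)ethyl group would address. Also open, going by these compounds, is how a carboxylic acid in place of the hydroxycarbamoyl group would read out.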